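Removing the amide ethyl group from an orexin-1 antagonist

The source may hold more compounds than are shown below. What is called first, only, known or untested is meant among the compounds shown, and "the series" means these compounds.

Compound 1 `CCN(C(=O)c1cc(C)ccc1-n1nccn1)[C@@H](C)Cn1ccc(-c2ccc(F)cn2)n1` has the lowest number of the three compounds measured in a functional assay on cells for antagonist activity at Orexin/Hypocretin receptor type 1 (Homo sapiens), read by fluorescence and calcium flux, with a stated time of 30 min (on this read-out higher numbers stand for weaker inhibition and lower numbers for stronger inhibition), where compound 1 gives 1.62 nM. Its nearest neighbour is compound 3 `Cc1ccc(-n2nccn2)c(C(=O)N(C)CCn2ccc(-c3ccc(F)cn3)n2)c1`, which in this assay gives 5.54 nM; compound 3 differs from compound 1 in more than one place, so only the two values themselves can be set side by side. Compound 2 `CCN(C(=O)c1cc(C)ccc1-n1nccn1)[C@H](C)Cn1ccc(-c2ccc(F)cn2)n1` is the mirror-image drawing of compound 1 at the chain stereocentre. In this assay compound 2 gives 86.6 nM, and the step of a 53-fold higher number from compound 1 to compound 2 (1.73 log units; beyond the scatter) shows how much the configuration matters, because the fact that compounds 1 and 2 differ only in the configuration as drawn is the only difference between them.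

Compound 4 `Cc1ccc(-n2nccn2)c(C(=O)N[C@@H](C)Cn2ccc(-c3ccc(F)cn3)n2)c1` keeps the configuration of compound 1 but carries hydrogen in place of ethyl on an amide-type nitrogen. Within the data shown here, no measured step addresses this change: the only single-point step, from compound 1 to compound 2, concerns configuration alone and gives no guidance on the amide substituent. The expectation for compound 4 therefore rests on the structural change itself, and a weakening step a 93-fold higher number from compound 1 to compound 4 (1.97 log units; beyond the scatter) is expected, with wide uncertainty. Compound 4 is estimated at 150 nM, in a range from 15 nM to 1500 nM.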

Compound 4, half-maximal inhibitory concentration: 10.1 nM
Compound 4: the middle estimate sits 15-fold (1.17 log units) above what was measured; the whole stated range lies above it.
By their numbers in this assay, from the lowest: compound 1; then compounds 3 and 4 (each within the scatter of the next); then compound 2.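

On the amide-type nitrogen, hydrogen in place of ethyl gives a 6.2-fold higher number from compound 1 to compound 4 (0.79 log units; beyond the scatter) in this assay, so the ethyl group lowers the number of compound 1, yet without it compound 4 still gives 10.1 nM. This step is smaller than a 53-fold higher number from compound 1 to compound 2 (1.73 log units; beyond the scatter), so among these compounds the configuration at the chain carbon moves the number further than removing the ethyl group does. Nothing in the data shown accounts for the size of the step at the nitrogen.

The compounds shown leave open whether the chain configuration carries the same weight once the ethyl group is gone. They also leave open how a propyl chain or a cyclopropyl group on the same nitrogen would read in this assay, and so whether the number could fall further than for compound 1.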